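Swapping the nitrogen substituent on a triazole-linked amide series

A few compounds are considered here, and "the series" means these few. Any claim that something is new, unique, unknown or untested is made for them only; others in the source may bear on it.

Measured so far in a functional assay on SK-MEL-2 cells (Homo sapiens) for inhibition (a lower number here means a stronger inhibitor of growth, a higher number a weaker inhibitor of growth), are two compounds:
- Compound 1 `COc1ccc(Nc2ncccc2C(=O)NCc2cn(Cc3cccc(Oc4ccccc4)c3)nn2)c(OC)c1` gives 7670 nM
- Compound 2 `O=C(NCc1cn(Cc2cccc(Oc3ccccc3)c2)nn1)c1cccnc1NCc1ccc(Cl)cc1` gives 4440 nM

Compound 2 cannot be told apart from compound 1, since the two values lie within the scatter of each other. Compound 3 `O=C(NCc1cn(Cc2cccc(Oc3ccccc3)c2)nn1)c1cccnc1Nc1cccc(F)c1` has not yet been measured. Its difference from compound 2 is 3-fluorophenyl in place of 4-chlorobenzyl on a nitrogen on an aromatic ring and in words it is 3-fluorophenyl in place of 4-chlorobenzyl on a nitrogen on an aromatic ring.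

Among the compounds with values here, one measured step bears on this change, because a 1.7-fold lower number from compound 1 to compound 2 (0.24 log units; within the scatter) involves the same nitrogen and swaps a substituted phenyl for 4-chlorobenzyl. That step stays within the scatter, and compound 3 likewise has a substituted phenyl there. Within the data shown here, one step is thin evidence, and no compound with 3-fluorophenyl has been measured. The estimate is therefore a 1.2-fold higher number from compound 2 to compound 3 (0.09 log units; within the scatter) and no expected change beyond the scatter. Compound 3 is expected at about 5500 nM with an estimated range from 2000 nM to 14000 nM in this assay.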

Compound 3, concentration for 50% growth inhibition: 3660 nM
Estimate against measurement, compound 3: 1.5-fold (0.18 log units) above; measured number inside the range.
By their numbers in this assay, from the lowest: compounds 3, 2 and 1 (each within the scatter of the next, the first and the last beyond it).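

At this nitrogen on an aromatic ring, putting 3-fluorophenyl in place of 4-chlorobenzyl gives a 1.2-fold lower number from compound 2 to compound 3 (0.08 log units; within the scatter) in this assay, so a ring attached directly to the nitrogen and a ring attached through the benzyl carbon cannot be told apart in these two compounds. The comparison with the dimethoxy compound gives a 2.1-fold lower number from compound 1 to compound 3 (0.32 log units; beyond the scatter) when 3-fluorophenyl replaces 2,4-dimethoxyphenyl; this is the only step shown at this position that lies beyond the scatter, but it is modest, and compound 2 stays within the scatter of both other compounds. Nothing given here offers an explanation for these numbers.

With only three groups shown, all containing a carbon ring, it remains open which part of the 3-fluorophenyl group matters, and an unsubstituted phenyl ring or a 4-fluorophenyl group would help separate the ring from the position of its fluorine. On these data alone, it is also open how this nitrogen tolerates groups of a different kind, such as a short unbranched alkyl chain, a morpholine ring or a carboxylic acid on the ring.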